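Amide Swap on a Chroman Core: From Compound 2 Toward Compound 3

This account rests on a few compounds, and the source may have more. Where it says the series, first, only, none or still open, it means among the compounds named here.

Measured so far:
compound 1 `Cc1c(C)c2c(c(C)c1O)CCC(C)(C(=O)N1CCN(c3cc(N4CCCC4)nc(N4CCCC4)n3)CC1)O2`, 500 nM in a functional assay (brain) for inhibition, with Rattus norvegicus as the target; a higher number here means a weaker inhibitor, a lower number a stronger inhibitor
compound 2 `Cc1c(C)c2c(c(C)c1O)CCC(C)(C(=O)N1CCCC1)O2`, 10000 nM in this assay

Compound 2 stands at the highest of the two numbers in this assay; compound 1 gives a lower number, by a margin beyond the usual scatter. Compound 3 `Cc1c(C)c2c(c(C)c1O)CCC(C)(C(=O)Nc1ccccn1)O2` differs from compound 2 in one place: (pyridin-2-yl)amino in place of pyrrolidin-1-yl on a carbonyl carbon. Going by the values given here, with no measured step of this kind available, only a small change is expected, if any, in this assay, in either direction within the scatter: a 1.4-fold lower number from compound 2 to compound 3 (0.15 log units; within the scatter). Compound 3 is therefore estimated at 7000 nM, within a range from 1500 nM to 30000 nM.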

Compound 3, half-maximal inhibitory concentration: 1800 nM
For compound 3 the middle estimate is 3.9-fold (0.59 log units) above the measured one; the measured number falls inside the stated range.
By their numbers in this assay, from the lowest: compound 1; then compound 3; then compound 2.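

In this assay the group on the carbonyl carbon clearly matters: (pyridin-2-yl)amino in place of pyrrolidin-1-yl gives a 5.6-fold lower number from compound 2 to compound 3 (0.74 log units; beyond the scatter) with the rest of the molecule unchanged. Going by these compounds alone, this is the first single-place comparison at this position, and it shows that the position responds to a change of amide group. Nothing available explains this step.

It remains open which part of the entering group accounts for the step. A phenylamino or (pyridin-3-yl)amino group on the same carbonyl carbon would help separate the contribution of the ring nitrogen from that of the amide hydrogen.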